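Reversing the oxolane gain in the dimethylpyridone lactam series

A few compounds are considered here, and "the series" means these few. Any claim that something is new, unique, unknown or untested is made for them only; others in the source may bear on it.

Compound 3 `Cc1cc(C)c(CN2CCc3c(Cl)cc([C@H](CO)[C@H]4CCOC4)c(Cl)c3C2=O)c(=O)[nH]1` gives the lowest number of the three measured compounds in an assay for inhibition of histone-lysine N-methyltransferase EZH2 variant Y641N (Homo sapiens), read by scintillation counting, with a stated time of 60 min, in the presence of a further agent that is not named here; a lower number here means a stronger inhibitor, a higher number a weaker inhibitor: compound 3 gives 0.24 nM. Its nearest neighbour is compound 2 `Cc1cc(C)c(CN2CCc3c(Cl)cc([C@@H](CO)[C@H]4CCCO4)c(Cl)c3C2=O)c(=O)[nH]1`, which in this assay gives 110 nM, and the furthest is compound 1 `Cc1cc(C)c(CN2CCc3c(Cl)cc([C@@H](C)CO)c(Cl)c3C2=O)c(=O)[nH]1`, which gives 260 nM; both gaps lie beyond the scatter, as seen in a 460-fold lower number from compound 2 to compound 3 (2.66 log units; beyond the scatter) and a 1100-fold lower number from compound 1 to compound 3 (3.03 log units; beyond the scatter).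

Compound 4 `Cc1cc(C)c(CN2CCc3c(Cl)cc([C@H](C)CO)c(Cl)c3C2=O)c(=O)[nH]1` is the next compound to be measured in this assay. Relative to compound 3 the change is a group of 4 heavy atoms (3 carbon, 1 oxygen; no ring) in place of a group of 8 heavy atoms (6 carbon, 2 oxygen; one five-membered non-aromatic ring with 1 hetero atom), on an aromatic carbon, on an aromatic carbon of a six-membered aromatic ring of carbon only, part of a fused or bridged system of two rings, ortho to a chloro group and meta to a chloro group.

For the measured compounds named here, the step that bears directly on this change is the one from compound 1 to compound 3, where oxolan-3-yl in place of methyl gave a 1100-fold lower number from compound 1 to compound 3 (3.03 log units; beyond the scatter). Going by the values given here, compound 4 runs that change backwards, with a different defined stereocentre on the remaining chain than compound 1 carries, for which no measured step exists. A large step upward in the number is therefore expected, roughly undoing the earlier gain: a 1300-fold higher number from compound 3 to compound 4 (3.10 log units; beyond the scatter). Compound 4 is estimated at 300 nM, within a range of 60 nM to 1500 nM.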

Compound 4, inhibition constant in the histone-lysine N-methyltransferase EZH2 assay: 17 nM
For compound 4 the middle estimate is 18-fold (1.25 log units) above the measured one; measured number outside the range, below it.
By their numbers in the histone-lysine N-methyltransferase EZH2 assay, from the lowest: compound 3; then compound 4; then compound 2; then compound 1.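

In the histone-lysine N-methyltransferase EZH2 assay, inverting the drawn stereocentre from R to S with the same atoms and bonds gives a 15-fold lower number from compound 1 to compound 4 (1.18 log units; beyond the scatter), so configuration alone moves the number at this chain carbon: the fact that compounds 1 and 4 differ only in the configuration as drawn With that configuration, removing the ring still leaves a 71-fold higher number from compound 3 to compound 4 (1.85 log units; beyond the scatter), a smaller penalty than the gap between compound 3 and the R chain of compound 1, while methyl in place of oxolan-2-yl gives a 6.5-fold lower number from compound 2 to compound 4 (0.81 log units; beyond the scatter), so the two oxolane compounds pull in opposite directions relative to compound 4. In a physicochemical assay for lipophilicity, at pH 7.4 (on this read-out higher numbers stand for higher lipophilicity and lower numbers for lower lipophilicity), compound 3 gives 2 and compound 4 gives 2.6, so compound 3 combines the lower number on this read-out with the lower number in the histone-lysine N-methyltransferase EZH2 assay.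

The compounds shown do not separate the attachment point of the oxolane ring from the configuration of the chain carbon that carries it, since no oxolan-3-yl and oxolan-2-yl pair is matched for configuration. Going by these compounds, it also remains open whether the gain needs the ring oxygen, as a cyclopentyl group or a pyrrolidin-3-yl amine at the same carbon would show.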